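The source may hold more compounds than are shown below. What is called first, only, known or untested is meant among the compounds shown, and "the series" means these compounds.

Working notes on the series in a functional assay on SK-OV-3 cells (Homo sapiens) for inhibition, read by CCK-8 assay, with a stated time of 70 h; a higher number here means a weaker inhibitor, a lower number a stronger inhibitor. Compound 1 `O=C(O)c1cccc(COc2ccc(OCCOCCNC3CCCC3)cc2)c1` reads > 100000 nM, which is a limit of the assay and not a number. Compound 2 `Cc1ccc(COc2ccc(OCCOCCNC3CCCC3)cc2)cc1` gives 17200 nM. Compound 3 `O=Cc1ccc(COc2ccc(OCCOCCNC3CCCC3)cc2)cc1` gives 45000 nM, the higher of the two actual numbers in this assay.

Compound 4 `COC(=O)c1ccccc1COc1ccc(OCCOCCNC2CCCC2)cc1` carries 2-(methoxycarbonyl)phenyl in place of 4-formylphenyl on a saturated chain carbon bound to an oxygen on an aromatic ring.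

Among the compounds with values here, three measured steps bear on this change, all at the same place or on the same ring. The two from the limit are an at least 5.8-fold lower number from compound 1 to compound 2 (0.76 log units; beyond the scatter) and an at least 2.2-fold lower number from compound 1 to compound 3 (0.34 log units; beyond the scatter), and both are only bounds. Within the data shown here, the one fully numerical step is modest: a 2.6-fold higher number from compound 2 to compound 3 (0.42 log units; beyond the scatter). On the strength of that step, only a small shift is expected, with no clear direction and probably none beyond the scatter.

The expected step is a 1.1-fold lower number from compound 3 to compound 4 (0.05 log units; within the scatter). The estimate for compound 4 is 40000 nM, with an expected range of 15000 nM to 100000 nM.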

Compound 4, half-maximal inhibitory concentration: > 100000 nM
Compound 4 ended at the assay's limit; the forecaster's own chance of this, stated with the estimate: 15%; middle value at least 2.5-fold (0.39 log units) away from the limit.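

In this assay compound 4 reads > 100000 nM, which is a limit of the assay and not a number. On the saturated chain carbon bound to an oxygen on an aromatic ring, 2-(methoxycarbonyl)phenyl gives an at least 2.2-fold higher number from compound 3 to compound 4 (0.34 log units; beyond the scatter) and an at least 5.8-fold higher number from compound 2 to compound 4 (0.76 log units; beyond the scatter). Among the earlier compounds only the 3-carboxyphenyl compound sat at the limit, whereas 2-(methoxycarbonyl)phenyl, with no net charge, now sits there too, and the step between these two compounds cannot be read: the limit of > 100000 nM in this assay, at which 2 of the 4 values shown sit.

The compounds shown do not separate the methoxycarbonyl group itself from its placement in 2-(methoxycarbonyl)phenyl, as no other placement of that group appears among them. On these data alone, how a primary amide or an amine on the same ring would read in this assay also remains open.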